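The source may hold more compounds than are shown below. What is called first, only, known or untested is meant among the compounds shown, and "the series" means these compounds.

Compound 1 `Cc1c(O)ccc2c1[C@H](Cn1cc(-c3ccccc3)nn1)[C@@]13CC(=O)[C@@](C)(CC[C@@H]21)C3`, compound 2 `Cc1ccc(S(=O)(=O)Oc2ccc3c(c2C)[C@H](Cn2cc(-c4ccccc4)nn2)[C@@]24CC(=O)[C@@](C)(CC[C@@H]32)C4)cc1` and compound 3 `Cc1ccc(S(=O)(=O)Oc2ccc3c(c2C)[C@H](Cn2cc(-c4ccccn4)nn2)[C@@]24CC(=O)[C@@](C)(CC[C@@H]32)C4)cc1` were tested in a functional assay on HL-60 cells (Homo sapiens) for cytotoxicity, read by MTT assay, with a stated time of 4 days; a lower number here means a stronger inhibitor, a higher number a weaker inhibitor. In this assay compound 1 gives > 20000 nM, which is a limit of the assay and not a number. Compound 2 gives > 20000 nM in this assay, again a limit. Compound 3 gives > 20000 nM in this assay, also a limit. Compound 4 `Cc1c(O)ccc2c1[C@H](Cn1cc(-c3ccccn3)nn1)[C@@]13CC(=O)[C@@](C)(CC[C@@H]21)C3` has not yet been measured in this assay.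

Compound 4 differs from compound 3 by hydrogen in place of (4-methylphenyl)sulfonyl on an oxygen on an aromatic ring. The same change separates compound 1 from compound 2, (hydrogen in place of (4-methylphenyl)sulfonyl on an oxygen on an aromatic ring), and the surroundings of the changed oxygen are the same in both pairs. The cores of the two pairs differ by pyridin-2-yl in place of phenyl on an aromatic carbon. The step that the change made, a step that the two limits leave unreadable from compound 2 to compound 1, cannot be sized; the limit of > 20000 nM in this assay, at which 3 of the 3 values shown sit, holds both of its ends.

For compound 4 the step that the limit leaves unreadable from compound 3 to compound 4 is expected to be likewise unreadable, an expectation resting on the limit of > 20000 nM in this assay, at which 3 of the 3 values shown sit, and on the unreadable step that the two limits leave unreadable from compound 2 to compound 1. Compound 4 is therefore estimated at 30000 nM, most likely between 15000 nM and 100000 nM.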

Compound 4, half-maximal inhibitory concentration: > 20000 nM
Compound 4: a limit, no number; the forecaster's own chance of this, stated with the estimate: 85%; the middle value lies beyond the limit too.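

In this assay neither the step from compound 3 to compound 4 nor the step from compound 1 to compound 4 can be read, because both ends of each step are limits and not numbers: the limit of > 20000 nM in this assay, at which 4 of the 4 values shown sit. The compounds shown leave open whether hydrogen in place of (4-methylphenyl)sulfonyl, or pyridin-2-yl in place of phenyl, changes the read-out at all.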